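The source may hold more compounds than are shown below. What is called first, only, known or untested is meant among the compounds shown, and "the series" means these compounds.

Of the compounds shown here, two of the same core have been measured. Compound 1, `CC1(C)OC[C@@H](C/C=C\CCC(=O)O)[C@@H](c2cccnc2)O1`, carries a pyridin-3-yl group on a saturated ring carbon, and in an assay on isolated protein for inhibition of Thromboxane-A synthase (Homo sapiens) (a lower number here means a stronger inhibitor, a higher number a weaker inhibitor), compound 1 gives 120 nM. Compound 2, `CC1(C)OC[C@@H](C/C=C\CCC(=O)O)[C@@H](c2ccnnc2)O1`, carries a pyridazin-4-yl group at the same place, and in this assay compound 2 gives 7400 nM. For the measured compounds named here, the one step between them, a 62-fold higher number from compound 1 to compound 2 (1.79 log units; beyond the scatter), is the only comparison available, and it leaves compound 2 with the highest number of the two, far beyond the scatter from compound 1.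

Compound 3, `CC1(C)OC[C@@H](C/C=C\CCC(=O)O)[C@@H](c2cnccn2)O1`, differs from compound 2 only by pyrazin-2-yl in place of pyridazin-4-yl on a saturated ring carbon. Going by the values given here, no measured step covers this exact exchange of one two-nitrogen ring for another. The step from compound 1 to compound 2 shows that moving from one aromatic ring to a related one at this position can shift the number a great deal, and in that case the shift was toward a weaker inhibitor. Among the compounds with values here, with no direct precedent, a step of about a 1.6-fold higher number from compound 2 to compound 3 (0.21 log units; within the scatter) is expected, which is within the scatter of the number for compound 2. The estimate for compound 3 in this assay is therefore 12000 nM, with a range from 2500 nM to 60000 nM.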

Compound 3, half-maximal inhibitory concentration: > 10000 nM
Compound 3: no number, only a limit; the forecaster's own chance of this, stated with the estimate: 15%; the middle value does not contradict the limit.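

The reading for compound 3 is a limit of the assay and not a number: the limit of > 10000 nM in this assay, at which 1 of the 3 values shown sits. Pyrazin-2-yl in place of pyridin-3-yl gives an at least 83-fold higher number from compound 1 to compound 3 (1.92 log units; beyond the scatter), so a second ring with two nitrogens on this saturated ring carbon also lands far from the pyridin-3-yl result, whereas the earlier pair showed this for pyridazin-4-yl alone. The exchange of one such ring for the other gives an at least 1.3-fold higher number from compound 2 to compound 3 (0.13 log units; that floor lies within the scatter), and since this is only a floor that lies within the scatter, the true gap could be small or large and the two rings cannot be put in order in this assay.

These compounds leave open how far beyond its limit the true value of compound 3 lies. They also leave open whether a ring with a single nitrogen placed differently, such as pyridin-4-yl, or a plain phenyl ring on this carbon would give a number closer to that of compound 1 than the two-nitrogen rings do.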